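From 4-methylphenyl to pyridin-3-yl in compound 2

A few compounds are considered here, and "the series" means these few. Any claim that something is new, unique, unknown or untested is made for them only; others in the source may bear on it.

Measured values in a physicochemical assay for solubility, read by LC-MS, using the shake flask method, measured as thermodynamic solubility, with a stated time of 24 h, at pH 6.5; a lower number here means a less soluble compound, a higher number a more soluble compound
Compound 1 `OC[C@H]1O[C@H](n2cc(-c3ccc(C(F)(F)F)cc3)nn2)[C@@H](O)[C@@H](O)[C@@H]1O` gives 159 ug/mL
Compound 2 `Cc1ccc(-c2cn(C[C@H]3O[C@H](CO)[C@@H](O)[C@H](O)[C@@H]3O)nn2)cc1` gives 1490 ug/mL
Compound 3 `OC[C@H]1O[C@H](Cn2cc(-c3ccc(C(F)(F)F)cc3)nn2)[C@@H](O)[C@@H](O)[C@@H]1O` gives 525 ug/mL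

Compound 2 stands highest of these three, with compound 3 and compound 1 both lower on the numbers shown. Compound 4 `OC[C@H]1O[C@H](Cn2cc(-c3cccnc3)nn2)[C@@H](O)[C@@H](O)[C@@H]1O` has not yet been measured. It differs from compound 2 as follows: pyridin-3-yl in place of 4-methylphenyl on an aromatic carbon so that pyridin-3-yl stands in place of 4-methylphenyl on an aromatic carbon.

Among the measured compounds shown here, one measured step bears on this change, namely a 2.8-fold lower number from compound 2 to compound 3 (0.45 log units; beyond the scatter) when trifluoromethyl takes the place of methyl on an aromatic carbon. That step is modest, and it changes the same aromatic group that changes here. For the measured compounds named here, it brings in no ring nitrogen, however, so no measured compound tests this swap directly. A step of similar modest size is therefore expected, with the direction a matter of judgement. The entering group counts one hydrogen-bond acceptor where the leaving group counts none, so an upward move is expected, though a result near compound 2 would not surprise. The estimated change is a 2.3-fold higher number from compound 2 to compound 4 (0.37 log units; beyond the scatter) and it carries wide uncertainty. Compound 4 is estimated at 3500 ug/mL within an expected range (1100 ug/mL to 10000 ug/mL).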

Compound 4, solubility: 1880 ug/mL
Compound 4: the middle estimate sits 1.9-fold (0.27 log units) above what was measured, and the stated range covers the measured number.
By their numbers in this assay, from the lowest: compound 1; then compound 3; then compounds 2 and 4 (each within the scatter of the next).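

In this assay, replacing the whole 4-methylphenyl ring with pyridin-3-yl gives a 1.3-fold higher number from compound 2 to compound 4 (0.10 log units; within the scatter), so this place on the five-membered aromatic ring with 3 nitrogen accepts a ring with 1 hetero atom and a hydrogen-bond acceptor without a step that can be told from the scatter. Among the compounds shown here, the only earlier change to this aromatic group, a 2.8-fold lower number from compound 2 to compound 3 (0.45 log units; beyond the scatter), altered a group on the benzene ring and lay beyond the scatter, so the series now holds one change here that can be read and one that cannot, and the size of a change at this place cannot be judged from the group's name alone. Nothing available here accounts for either outcome.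

Whether the result depends on where the ring nitrogen lies remains open, as pyridin-2-yl, pyridin-4-yl and a pyrimidine ring are absent from the compounds shown. Also open, as far as these compounds go, is how pyridin-3-yl would read on the core of compound 1, which gives 159 ug/mL with its trifluoromethyl-bearing ring, and whether an amine or a carboxylic acid on the aromatic ring would move the number beyond the scatter.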